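The source may report more compounds than this note shows. Statements on the series, on what has been measured and on what is new or still open speak of the compounds shown alone.

The measured compounds:
- compound 1, `COc1cc(NC(=O)C2CCC3(CC2)OOC2(OO3)C3CC4CC(C3)CC2C4)c2ncccc2c1-c1ccccc1`, which in an ADME assay on microsomes from liver (Rattus norvegicus) for metabolic stability, read by HPLC, using NADPH, tested at 1 mM (a higher number here means faster removal of the compound, a lower number slower removal), gives 33 uL/min
- compound 2, `COc1cc(NC(=O)C2CCC3(CC2)OOC2(OO3)C3CC4CC(C3)CC2C4)c2ncccc2c1-c1ccc(F)cc1`, which in this assay gives 23.1 uL/min

Within the data shown here, compound 2 stands as the lower of the two numbers recorded so far, but its only neighbour is compound 1, and the step of a 1.4-fold lower number from compound 1 to compound 2 (0.15 log units; within the scatter) shows that the two values cannot be told apart. Compound 3, `COc1cc(NC(=O)C2CCC3(CC2)OOC2(OO3)C3CC4CC(C3)CC2C4)c2ncccc2c1-c1ccc(Cl)cc1`, has not yet been measured. It differs from compound 2 in one place: chloro in place of fluoro on an aromatic carbon.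

Among the measured compounds shown here, the single measured step that bears on this change is a 1.4-fold lower number from compound 1 to compound 2 (0.15 log units; within the scatter), in which the same aromatic carbon carried fluoro in place of hydrogen and the readout moved only within the scatter. For the measured compounds named here, no measured pair in this set puts chloro against fluoro directly, so the evidence for a substituent effect at this carbon is thin. The expected step in this assay is therefore a 1.1-fold higher number from compound 2 to compound 3 (0.03 log units; within the scatter), a shift that is not expected to rise beyond the scatter. Compound 3 is accordingly estimated at 25 uL/min, with a range from 12 uL/min to 50 uL/min.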

Compound 3, intrinsic clearance in a liver preparation (reported as CLH), per the amount of preparation that the assay uses: 11.1 uL/min
The estimate for compound 3 lay 2.3-fold (0.35 log units) above the measured number, and the stated range ends above it.
By their numbers in this assay, from the lowest: compound 3; then compounds 2 and 1 (each within the scatter of the next).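

In this assay, among these compounds, the change to the 4-chlorophenyl group gives the only steps in this small set that lie beyond the scatter (a 2.1-fold lower number from compound 2 to compound 3 (0.32 log units; beyond the scatter)) and (a 3.0-fold lower number from compound 1 to compound 3 (0.47 log units; beyond the scatter)). The group on this aromatic carbon, para to a large group, can therefore move the read-out, which the exchange of hydrogen for fluoro did not show (a 1.4-fold lower number from compound 1 to compound 2 (0.15 log units; within the scatter)), and chloro stands apart from both fluoro and hydrogen, whose values lie within the scatter of each other. The data offer no measurement that explains why chloro differs from fluoro at this carbon.

As far as these compounds go, with only hydrogen, fluoro and chloro at this carbon, it remains open whether the read-out would keep falling or turn back with bromo, methyl, methoxy, nitrile, an amine or a carboxylic acid in the same place. All three compounds also share the same core, so whether the chloro step would hold on a different core, or with chloro elsewhere on the six-membered aromatic ring, remains unanswered.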